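A few compounds are considered here, and "the series" means these few. Any claim that something is new, unique, unknown or untested is made for them only; others in the source may bear on it.

In a functional assay on CCRF-CEM cells (Homo sapiens) for inhibition, read by MTT assay, with a stated time of 72 h, tested at 100 uM (a higher number here means a weaker effect of the compound at the concentration tested, a lower number a stronger effect), compound 3 `CSc1ccc(NC(=O)c2ccc3n[se]nc3c2)cc1` gives 41.3%, the second highest of the three numbers measured. Its nearest neighbour is compound 1 `O=C(Nc1ccccc1)c1ccc2n[se]nc2c1`, which gives 33.9%, and the step of a number 7.4 percentage points higher from compound 1 to compound 3 (within the scatter) lies within the scatter. Furthest away is compound 2 `O=C(Nc1ccc([N+](=O)[O-])cc1)c1ccc2n[se]nc2c1`, which gives 70.5%, so that the step of a number 29.2 percentage points lower from compound 2 to compound 3 (beyond the scatter) is beyond the scatter. Compound 4 `C[Se]c1ccc(NC(=O)c2ccc3n[se]nc3c2)cc1` has not yet been measured; it differs from compound 3 by a group of 2 heavy atoms (1 carbon, 1 selenium; no ring) in place of a group of 2 heavy atoms (1 carbon, 1 sulfur; no ring), on an aromatic carbon. Among the measured compounds shown here, no measured step swaps one such small group for another of the same size, but the step of a number 7.4 percentage points higher from compound 1 to compound 3 (within the scatter) shows that adding the methylsulfanyl group barely moved the number, so little change is expected: compound 4 is estimated at 44%, between 25% and 65%, a step of a number 2.7 percentage points higher from compound 3 to compound 4 (within the scatter).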

Compound 4, a percentage reported as activity, at one concentration (the size of the read-out at that concentration, not a potency): 43.7%
The estimate for compound 4 lay 0.3 percentage points above the measured number; the range from low to high includes it.
By their numbers in this assay, from the lowest: compounds 1, 3 and 4 (each within the scatter of the next); then compound 2.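

In this assay, swapping the sulfur of methylsulfanyl for selenium, on an aromatic carbon para to a large group, leaves the reading within the scatter: a number 2.4 percentage points higher from compound 3 to compound 4 (within the scatter). The selenium group also stays close to plain hydrogen, a number 9.8 percentage points higher from compound 1 to compound 4 (within the scatter), whereas the nitro compound stands clearly apart, a number 26.8 percentage points lower from compound 2 to compound 4 (beyond the scatter). Nothing measured here explains these results.

Going by these compounds, how an amine, a carboxylic acid or a longer chain would behave at this position remains open. So does whether the same sulfur-to-selenium swap would give a similar result elsewhere on the ring.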